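Methoxy position shift on the anilide of compound 2

The source may report more compounds than this note shows. Statements on the series, on what has been measured and on what is new or still open speak of the compounds shown alone.

Measured so far in a functional assay on T47D cells (Homo sapiens) for inhibition, read by CCK-8 assay, with a stated time of 72 h, tested at 1 uM; a higher number here means more inhibition of growth at the concentration tested, a lower number less inhibition of growth:
compound 1, `CN(C)C(=O)c1cc2cnc(Nc3ccc(NC(=O)C4(C(=O)Nc5cccc(Cl)c5)CC4)cc3)nc2n1C1CCCC1`, gives 39.3%
compound 2, `COc1cccc(NC(=O)C2(C(=O)Nc3ccc(Nc4ncc5cc(C(=O)N(C)C)n(C6CCCC6)c5n4)cc3)CC2)c1`, gives 56.3%

Compound 2 stands highest of the two numbers; its nearest neighbour is compound 1, and the step reads a number 17 percentage points higher from compound 1 to compound 2 (beyond the scatter). For the measured compounds named here, that step exchanges chloro for methoxy on an aromatic carbon while the attachment point is held; it is the only measured step in the set.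

Compound 3, `COc1ccc(NC(=O)C2(C(=O)Nc3ccc(Nc4ncc5cc(C(=O)N(C)C)n(C6CCCC6)c5n4)cc3)CC2)cc1`, has the same atoms as compound 2 joined differently: 4-methoxyphenyl in place of 3-methoxyphenyl on an amide-type nitrogen. The group sits on an amide-type nitrogen whose other neighbour is a carbonyl carbon.

Going by the values given here, no measured step moves a group around this ring. The step from compound 1 to compound 2 changes the group itself, not its position, so it gives no direct guide to either size or direction here. Among the compounds with values here, with no bearing step, the working expectation for this assay is a step no larger than the scatter, with wide uncertainty either way. Compound 3 is therefore expected at 50%, with a range from 30% to 70%. The expected step is a number 6.3 percentage points lower from compound 2 to compound 3 (within the scatter).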

Compound 3, percent growth inhibition at one concentration: 76.4%
Compound 3: middle estimate off by 26.4 percentage points, on the low side; the whole stated range lies below it.
By their numbers in this assay, from the lowest: compound 1; then compound 2; then compound 3.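

In this assay, the anilide depends on where the methoxy sits as well as on which group is present: with the atom count unchanged, exchanging 3-methoxyphenyl for 4-methoxyphenyl on the amide-type nitrogen gives a number 20.1 percentage points higher from compound 2 to compound 3 (beyond the scatter) in this series. Set against the 3-chlorophenyl of the earlier comparison, the 4-methoxyphenyl group gives a number 37.1 percentage points higher from compound 1 to compound 3 (beyond the scatter), and compound 3 now holds the highest of the three numbers, with its steps to both other compounds beyond the scatter. Nothing available to these notes bears on why the placement of the methoxy changes the growth inhibition.

The compounds shown leave open whether the 4-position of this anilide ring tolerates other groups, for instance ethoxy, a dimethylamino group or a carboxylic acid in place of the methoxy of compound 3, and whether any of them would keep the higher number. Also open, on these data alone, is how the three compounds compare across a range of concentrations and in other cell lines, since a single concentration in one cell line is all that these numbers cover.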